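A few compounds are considered here, and "the series" means these few. Any claim that something is new, unique, unknown or untested is made for them only; others in the source may bear on it.

Measured compounds:
compound 1 `CC(=O)N1CCC(C(=O)N2N=CCC2c2ccccc2)CC1`: 2.5
compound 2 `CN1CCN(C(=O)C(C)(C)C)C(c2ccccc2)C1`: 4.9

In a physicochemical assay for lipophilicity, read by HPLC, measured as chromatographic lipophilicity, at pH 7.4 (a lower number here means a more polar compound, a higher number a more lipophilic compound), compound 1 gives 2.5, the lower of the two numbers recorded. The nearest neighbour is compound 2, which in this assay gives 4.9, a number well beyond the scatter of repeated measurement above that of compound 1. Within the data shown here, no single-point step links the two measured compounds, so their values are simply reported side by side.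

The unmeasured compound 3 `O=C(c1cc[nH]n1)N1CCC(C(=O)N2N=CCC2c2ccccc2)CC1` is derived from compound 1 by one change, (1H-pyrazol-3-yl in place of methyl on a carbonyl carbon). This is the acetyl to (1H-pyrazol-3-yl)carbonyl exchange, on a carbonyl carbon whose other neighbour is an amide-type nitrogen in a ring. For this change in this assay a modest downward step is expected, possibly no larger than the scatter.

The step from compound 1 to compound 3 is estimated at a number 0.30 log units lower from compound 1 to compound 3 (within the scatter). Compound 3 is therefore expected to give 2.2 in this assay, within a range from 1.6 to 2.8.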

Compound 3, distribution coefficient: 2.4
Estimate against measurement, compound 3: 0.20 log units below, within the range that was stated.
By their numbers in this assay, from the lowest: compounds 3 and 1 (each within the scatter of the next); then compound 2.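

Among these compounds, the earlier compounds offered no single-point step, so this is the first reading of what a change at this place does. In this assay, putting 1H-pyrazol-3-yl in place of methyl on a carbonyl carbon, with an amide-type nitrogen in a ring as its other neighbour, gives a number 0.10 log units lower from compound 1 to compound 3 (within the scatter), so a group of five heavy atoms with a five-membered aromatic ring, a hydrogen-bond donor and a hydrogen-bond acceptor leaves the reading within the scatter of that of the methyl group. Nothing available offers an explanation for this outcome.

This single step leaves open whether a carboxylic acid, an aminomethyl group or a longer alkyl chain on the same carbonyl carbon would shift the reading beyond the scatter. It also leaves open whether the same exchange would behave alike on a different core, such as that of compound 2.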